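This account rests on a few compounds, and the source may have more. Where it says the series, first, only, none or still open, it means among the compounds named here.

So far three compounds have values in a functional assay on PC-3 cells (Homo sapiens) for antiproliferative activity, read by MTT assay, with a stated time of 48 h (a higher number here means a weaker inhibitor, a lower number a stronger inhibitor), as follows:
Compound 1 `CCn1c(C(=O)N(CCC#N)CCC#N)ccc1C(CC)(CC)c1ccc(OCCC(O)(CC)CC)c(C)c1`: > 50000 nM (a limit of the assay, not a number)
Compound 2 `C=CCN(C)C(=O)c1ccc(C(CC)(CC)c2ccc(OCCC(O)(CC)CC)c(C)c2)n1CC`: 12800 nM
Compound 3 `CCn1c(C(=O)Nc2cccc(C(F)(F)F)c2)ccc1C(CC)(CC)c1ccc(OCCC(O)(CC)CC)c(C)c1`: 23800 nM

Only two of these are true numbers, compound 2 among them, and they cannot be ranked, as the step between them stays inside the scatter (a 1.9-fold higher number from compound 2 to compound 3 (0.27 log units; within the scatter)). Compound 1 reports only a limit (the limit of > 50000 nM in this assay, at which 1 of the 3 values shown sits).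

Compound 4 `CCOC(=O)C(CC(=O)OC)NC(=O)c1ccc(C(CC)(CC)c2ccc(OCCC(O)(CC)CC)c(C)c2)n1CC` keeps the core of compound 2 and alters only the group on a carbonyl carbon (a group of 12 heavy atoms (7 carbon, 1 nitrogen, 4 oxygen; no ring) in place of a group of 5 heavy atoms (4 carbon, 1 nitrogen; no ring), on a carbonyl carbon). Among the measured compounds shown here, all the measured steps are swaps at this same kind of carbonyl carbon. One swap, to a larger group, left the number within the scatter (a 1.9-fold higher number from compound 2 to compound 3 (0.27 log units; within the scatter)). The other two steps separate compound 1 from both neighbours (an at least 3.9-fold lower number from compound 1 to compound 2 (0.59 log units; beyond the scatter)) and (an at least 2.1-fold lower number from compound 1 to compound 3 (0.32 log units; beyond the scatter)). Group size alone therefore does not order these values, since compound 1 carries a group of middling size. A swap here may change nothing, or it may lose the measurable effect altogether. A small upward move is expected (a 1.6-fold higher number from compound 2 to compound 4 (0.19 log units; within the scatter)), possibly no larger than the scatter. The estimate for compound 4 is 20000 nM with an expected range from 8000 nM to 50000 nM.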

Compound 4, half-maximal inhibitory concentration: 5840 nM
Estimate against measurement, compound 4: 3.4-fold (0.53 log units) above; the whole stated range lies above it.
By their numbers in this assay, from the lowest: compound 4; then compounds 2 and 3 (each within the scatter of the next). At a limit, above all of these: compound 1.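

In this assay, the compounds with true numbers had shown no step beyond the scatter at this carbonyl carbon, and the new group, which has no ring and carries a hydrogen-bond donor and hydrogen-bond acceptors, gives the first such steps: a 2.2-fold lower number from compound 2 to compound 4 (0.34 log units; beyond the scatter), and a 4.1-fold lower number from compound 3 to compound 4 (0.61 log units; beyond the scatter). Compound 1 stays a limit and not a number, so an at least 8.5-fold lower number from compound 1 to compound 4 (0.93 log units; beyond the scatter) is the largest step shown but has no exact size: the limit of > 50000 nM in this assay, at which 1 of the 4 values shown sits. Compound 4 is thus the strongest of the four, yet size does not order the series, as compound 3 also carries a large group and stays within the scatter of compound 2.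

The new group has two ester arms and an amide hydrogen, and compound 3 also has an amide hydrogen, so these compounds do not tell which part of the group goes with the lower number. Going by these compounds, it remains open whether a carboxylic acid in place of either ester, or a shorter chain carrying only one ester, would hold, lower or lose the value of compound 4 at 5840 nM.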